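A few compounds are considered here, and "the series" means these few. Any claim that something is new, unique, unknown or untested is made for them only; others in the source may bear on it.

The measured compounds: compound 1 `CC(C)N(Cc1cccc(OCCCCCC(=O)O)c1)C(=O)c1ccc(-c2cccc3ccccc23)cc1`; compound 2 `CC(C)N(Cc1cccc(OCCCCCC(=O)O)c1)C(=O)c1ccc(-c2cccc(Oc3ccccc3)c2)cc1`; compound 3 `CCOc1cccc(-c2ccc(C(=O)N(Cc3cccc(OCCCCCC(=O)O)c3)C(C)C)cc2)c1`. In an ADME assay on BJ cells (Homo sapiens) for cytotoxicity, read by CellTiter-Glo and resazurin assay, with a stated time of 72 h (a higher number here means that more compound is needed for the effect, a lower number that less compound is needed), compound 1 gives < 1.3 nM, which is a limit of the assay. Compound 2 gives > 18700 nM, also a limit. Compound 3 gives > 20800 nM, again a limit.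

Compound 3 thus stands at the upper edge of the numbers shown, with only a limit and no number for it, and both other compounds likewise sit at limits. Compound 4 `CC(C)N(Cc1cccc(OCCCCCC(=O)O)c1)C(=O)c1ccc(-c2cccc(O)c2)cc1` differs from compound 3 by hydrogen in place of ethyl on an oxygen on an aromatic ring. The step of an at least 16000-fold higher number from compound 1 to compound 3 (4.20 log units; beyond the scatter) changes a different part of the structure. The step that the two limits leave unreadable from compound 2 to compound 3 alters the same oxygen but runs between two limits. For the measured compounds named here, no measured step therefore reads directly on the change to hydrogen. Compound 4 is expected to remain at the limit, with an estimated step that the limit leaves unreadable from compound 3 to compound 4 of no readable direction. The estimate for compound 4 is 25000 nM, ranging from 5000 nM to 100000 nM.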

Compound 4, half-maximal effective concentration: > 26000 nM
Compound 4: only a limit was reported (the forecaster's own chance of this, stated with the estimate: 75%); middle value at least 1.0-fold (0.01 log units) from the limit.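

In this assay compound 4 gives > 26000 nM, which is a limit and not a number. With hydrogen, ethyl or phenyl on this oxygen, compound 4, compound 3 and compound 2 all sit at upper limits, so the steps among them cannot be read. The change from naphthalen-1-yl to 3-hydroxyphenyl gives an at least 20000-fold higher number from compound 1 to compound 4 (4.30 log units; beyond the scatter), a second large step at this aromatic carbon. On these data alone, the true numbers for compound 2, compound 3 and compound 4 stay open. So does whether an amine in place of the hydroxy, or a longer chain on the oxygen, would bring the number down from the limit.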